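The source may report more compounds than this note shows. Statements on the series, on what has been measured and on what is new or still open speak of the compounds shown alone.

The series rests on one shared core carrying a thiophene arm on a double-bonded chain carbon, and all of it was run through a functional assay on MCF7 cells (Homo sapiens) for antiproliferative activity, read by MTT assay, with a stated time of 72 h; on this read-out lower numbers stand for stronger inhibition and higher numbers for weaker inhibition. Compound 1 `C=C(Br)C(=O)Nc1ccc2c(c1)/C(=C\c1ccc(C)s1)C(=O)N2` carries a 5-methylthiophen-2-yl group, and in this assay compound 1 gives 4400 nM. Compound 2 `C=C(Br)C(=O)Nc1ccc2c(c1)/C(=C\c1sccc1C)C(=O)N2` differs from it in one place (3-methylthiophen-2-yl in place of 5-methylthiophen-2-yl on a double-bonded chain carbon bound to a double-bonded ring carbon), and in this assay compound 2 gives 2300 nM; the resulting step, a 1.9-fold lower number from compound 1 to compound 2 (0.28 log units; within the scatter), is small. Compound 3 `C=C(Br)C(=O)Nc1ccc2c(c1)/C(=C/c1ccc(C)s1)C(=O)N2` shares every atom and bond with compound 1, and in this assay compound 3 gives 3000 nM. The step of a 1.5-fold lower number from compound 1 to compound 3 (0.17 log units; within the scatter) is also small, a comparison that rests on (the fact that compounds 1 and 3 differ only in the configuration as drawn).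

Compound 4 `C=C(Br)C(=O)Nc1ccc2c(c1)/C(=C/c1sccc1C)C(=O)N2` has not yet been measured. It differs from compound 3 by 3-methylthiophen-2-yl in place of 5-methylthiophen-2-yl on a double-bonded chain carbon bound to a double-bonded ring carbon, the same change that separates compound 1 from compound 2, made here on the core of compound 3 rather than that of compound 1; the two cores differ only as the two compounds have the same atoms and bonds and differ only in configuration as drawn: 1 of 1 stereo elements differ; a double bond is drawn E in compound 1 and Z in compound 3. The place of the change is the same in both pairs. By analogy with a 1.9-fold lower number from compound 1 to compound 2 (0.28 log units; within the scatter), the step is expected to be a 1.8-fold lower number from compound 3 to compound 4 (0.25 log units; within the scatter), since compound 1 gives 4400 nM and compound 2 gives 2300 nM in this assay. In this assay compound 4 is therefore expected to give about 1700 nM, within a range from 800 nM to 3800 nM.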

Compound 4, half-maximal inhibitory concentration: 2600 nM
For compound 4 the middle estimate is 1.5-fold (0.18 log units) below the measured one; the measured number falls inside the stated range.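

Made on the core of compound 3, the exchange of 5-methylthiophen-2-yl for 3-methylthiophen-2-yl gives a 1.2-fold lower number from compound 3 to compound 4 (0.06 log units; within the scatter) in this assay, and the difference in double-bond configuration alone gives a 1.1-fold higher number from compound 2 to compound 4 (0.05 log units; within the scatter). Set side by side, the two steps for this exchange show no difference that can be told from ordinary scatter, so within these four compounds the exchange reads the same on both cores: the same change on two cores in this assay, a 1.9-fold lower number (0.28 log units; within the scatter) from compound 1 to compound 2 and a 1.2-fold lower number (0.06 log units; within the scatter) from compound 3 to compound 4, 1.7-fold (0.22 log units) apart, within the scatter of two such steps. This does not show that the exchange has a real effect on either core, because each step stays within the scatter, and agreement between two such small steps says little about how well a real effect would carry from one core to another: the same change on two cores in this assay, a 1.9-fold lower number (0.28 log units; within the scatter) from compound 1 to compound 2 and a 1.2-fold lower number (0.06 log units; within the scatter) from compound 3 to compound 4, 1.7-fold (0.22 log units) apart, within the scatter of two such steps.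

The compounds shown leave open how the antiproliferative read-out would respond to a different arm at the same place, such as an unsubstituted thiophene, a furan or a phenyl ring, or to a longer chain in place of the methyl group on the thiophene. They also leave open whether a change that gave a step beyond the scatter would carry between the two double-bond configurations in the same way.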